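Swapping the nitrile of compound 1 for a carboxylic acid

The source may hold more compounds than are shown below. What is called first, only, known or untested is meant among the compounds shown, and "the series" means these compounds.

Compound 1, with the structure `N#Cc1c(-c2ccccc2)nc(SCC(=O)Nn2c(COc3ccc(Cl)cc3Cl)nc3ccccc3c2=O)[nH]c1=O`, was tested in a functional assay on the whole organism (strain albino) for inhibition, with Rattus norvegicus as the target, read by paw edema, with stated times of 1 h and 3 h, at a dose of 100 mg/kg by the oral route (on this read-out higher numbers stand for a stronger effect at the one dose given and lower numbers for a weaker effect), where compound 1 gives 86%. Compound 2, `N#Cc1c(-c2ccc(O)cc2)nc(SCC(=O)Nn2c(COc3ccc(Cl)cc3Cl)nc3ccccc3c2=O)[nH]c1=O`, differs from compound 1 by a hydroxy in place of hydrogen on an aromatic carbon, and in this assay compound 2 gives 68.4%; the step of a number 17.6 percentage points lower from compound 1 to compound 2 (beyond the scatter) shows that this single change lowered the read-out. Among the two numbers so far, compound 1 stands highest.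

Compound 3, `O=C(CSc1nc(-c2ccccc2)c(C(=O)O)c(=O)[nH]1)Nn1c(COc2ccc(Cl)cc2Cl)nc2ccccc2c1=O`, has not yet been measured. Its change from compound 1 is carboxy in place of cyano on an aromatic carbon. Among the measured compounds shown here, this alteration sits on the shared core rather than on the phenyl ring, so the only measured step, from compound 1 to compound 2, does not touch the same place and gives no direct guide; it shows only that one change elsewhere cost a modest amount of inhibition.

For the measured compounds named here, with no matching precedent, the expected step is modest and downward at most: a number 16 percentage points lower from compound 1 to compound 3 (beyond the scatter). Compound 3 is estimated to give 70% in this assay, within a wide range from 48% to 86%.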

Compound 3, a percentage reported as inhibition, in the whole organism at one dose (the size of the read-out at that dose, not a potency): 64.9%
Compound 3: the middle estimate sits 5.1 percentage points above what was measured; the measured number falls inside the stated range.
By their numbers in this assay, from the lowest: compounds 3 and 2 (each within the scatter of the next); then compound 1.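

In this assay, the carbon that carries the nitrile on the six-membered aromatic ring with 2 nitrogen proves sensitive to change: putting carboxy there gives a number 21.1 percentage points lower from compound 1 to compound 3 (beyond the scatter), so a change on the shared core can move the read-out, just as the hydroxy added to the phenyl ring of compound 2 did. The swap replaces a group with a triple bond and no hydrogen-bond donor by a slightly larger one with a double bond and a hydrogen-bond donor, and this single step cannot show which of these differences matters. Nothing measured here explains the loss of effect.

The compounds shown leave open whether a primary amide or a methyl ester on this same carbon, each close in shape to the carboxylic acid but differing from it in the hydrogen it carries, would keep the read-out nearer to that of compound 1. They also leave open whether the step would look the same at other doses, since each compound is read at one dose only.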